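The source may hold more compounds than are shown below. What is called first, only, known or untested is meant among the compounds shown, and "the series" means these compounds.

Compound 1 `COc1ccc(Oc2ccc3cc(NC(=O)c4ccc(OC(C)=O)c(CC=C(C)C)c4)c(=O)oc3c2C)cc1` gives 18200 nM in a functional assay on MCF7 cells (Homo sapiens) for antiproliferative activity; a lower number here means a stronger inhibitor, a higher number a weaker inhibitor.
Compound 2 `COc1cccc(Oc2ccc3cc(NC(=O)c4ccc(OC)c(-c5cccc(OC)c5)c4)c(=O)oc3c2C)c1` reaches only the assay limit, > 100000 nM, in this assay.

Compound 2 thus stands at the limit of the two results shown (the limit of > 100000 nM in this assay, at which 1 of the 2 values shown sits), while compound 1 sits at a measured number. Compound 3 `COc1cccc(-c2cc(C(=O)Nc3cc4ccc(Cc5ccccc5)c(C)c4oc3=O)ccc2OC)c1` differs from compound 2 by benzyl in place of 3-methoxyphenoxy on an aromatic carbon. Among the measured compounds shown here, no measured pair shows this change, so its size is unknown; in this assay compound 3 is expected to remain weak, the shift from the limit not clearly beyond the scatter. The expected step is an at least 1.6-fold lower number from compound 2 to compound 3 (0.22 log units; that floor lies within the scatter). Compound 3 is estimated at 60000 nM, between 15000 nM and 200000 nM.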

Compound 3, half-maximal inhibitory concentration: 7110 nM
Beside the measured number, compound 3's estimate is 8.4-fold (0.93 log units) above it; measured number outside the range, below it.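

In this assay, the aromatic carbon ortho to a methyl group responds clearly to the group it carries: benzyl in place of 3-methoxyphenoxy gives an at least 14-fold lower number from compound 2 to compound 3 (1.14 log units; beyond the scatter). This is the first change at a single place among the compounds shown, and its size is a floor, since compound 2 sits at a limit of the assay rather than a number: the limit of > 100000 nM in this assay, at which 1 of the 3 values shown sits. The compounds shown leave open whether the difference follows from losing the methoxy group or the ether oxygen. Phenoxy or 3-methoxybenzyl at this position would separate the two.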